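Fluoro to Chloro Swap on a Fused Ring

A few compounds are considered here, and "the series" means these few. Any claim that something is new, unique, unknown or untested is made for them only; others in the source may bear on it.

Compound 1 `CCn1c(=O)/c(=C2\Sc3cc(F)ccc3N2C)s/c1=C\c1ccccn1` gives 5% in an ADME assay on microsomes from liver (Mus musculus) for metabolic stability, with a stated time of 30 min; a higher number here means that more of the compound is left, a lower number that less of the compound is left.
Compound 2 `CCn1c(=O)/c(=C2\Sc3c(F)cccc3N2C)s/c1=C\c1ccccn1` gives 12%.
Compound 3 `CCn1c(=O)/c(=C2\Sc3ccc(Cl)cc3N2C)s/c1=C\c1ccccn1` gives 37%.

Among these three, compound 1 shows the lowest number. Compound 2 sits only a little higher, a gap within the usual scatter of repeated measurements, so the two cannot be ranked. Compound 3 lies clearly higher, beyond the scatter, though its halogen sits at a different place, so no single-change comparison to compound 1 exists.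

Compound 4 `CCn1c(=O)/c(=C2\Sc3cc(Cl)ccc3N2C)s/c1=C\c1ccccn1` keeps the shared core of compound 1 and differs by chloro in place of fluoro on an aromatic carbon. For the measured compounds named here, no measured pair isolates this swap. A modest upward step is expected, a number 10 percentage points higher from compound 1 to compound 4 (within the scatter), but it may stay within the scatter. Compound 4 is estimated at 15%, plausibly between 4% and 35%.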

Compound 4, percent of the compound remaining: 13%
The estimate for compound 4 lay 2 percentage points above the measured number; the range from low to high includes it.
By their numbers in this assay, from the lowest: compounds 1, 2 and 4 (each within the scatter of the next); then compound 3.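

The swap of fluoro for chloro on this aromatic carbon can now be read on its own, and in this assay it gives a number 8 percentage points higher from compound 1 to compound 4 (within the scatter). At this position, then, these two halogens cannot be told apart by this read-out, and little of either compound remains. Nothing measured on hand explains this result.

Still open, going by these compounds, is whether a different kind of group on this carbon, such as a methoxy group, an amine or a nitrile, would leave more of the compound intact.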